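Nitro for bromo: one measured step carried to compound 4

The compounds below may be only part of what the source reports. "The series", "measured", "known", "first", "only" and "open" are said of these compounds alone.

Compound 1 `CCOc1ccc(NC(=O)c2cc3cc(Br)ccc3oc2=O)cc1` carries a bromo group and in a functional assay on HepG2 cells (Homo sapiens) for antiproliferative activity, read by fluorescence and resazurin assay, with a stated time of 48 h (on this read-out higher numbers stand for weaker inhibition and lower numbers for stronger inhibition), compound 1 gives 37000 nM. Compound 3 `CCOc1ccc(NC(=O)c2cc3cc([N+](=O)[O-])ccc3oc2=O)cc1` differs from compound 1 by nitro in place of bromo on an aromatic carbon. In this assay compound 3 gives 28300 nM. Compound 2 `O=C(N/N=C/c1cc2ccccc2nc1Cl)c1cc2cc(Br)ccc2oc1=O` has a different core; the difference between the two cores is not broken down here. In this assay compound 2 gives 9420 nM, the lowest of the three measured numbers, beyond the scatter from both compound 1 and compound 3. Compound 4 `O=C(N/N=C/c1cc2ccccc2nc1Cl)c1cc2cc([N+](=O)[O-])ccc2oc1=O` is not yet measured and differs from compound 2 by nitro in place of bromo on an aromatic carbon. This is the same change as that from compound 1 to compound 3, at the same place, and among the compounds shown it occurs twice in all. Going by the values given here, for compound 4 the expected step is a 1.3-fold lower number from compound 2 to compound 4 (0.12 log units; within the scatter), resting on the single measured example of this change, a 1.3-fold lower number from compound 1 to compound 3 (0.12 log units; within the scatter), which stayed within the scatter. Compound 4 is therefore expected to give about 7200 nM in this assay, with a range from 3000 nM to 18000 nM.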

Compound 4, half-maximal inhibitory concentration: 22800 nM
For compound 4 the middle estimate is 3.2-fold (0.50 log units) below the measured one; measured number above the stated range.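

In this assay, nitro in place of bromo on an aromatic carbon gives a 2.4-fold higher number from compound 2 to compound 4 (0.38 log units; beyond the scatter), so the step on the core of compound 2 is not the one seen on the core of compound 1. Set side by side, the two steps differ, and a step measured on one of these cores is not a safe guide to the other: the same change on two cores in this assay, a 1.3-fold lower number (0.12 log units; within the scatter) from compound 1 to compound 3 and a 2.4-fold higher number (0.38 log units; beyond the scatter) from compound 2 to compound 4, 3.2-fold (0.50 log units) apart, beyond the scatter of two such steps. Going by these compounds alone, with only one pair on each core, this shows that the outcome of the change depends on the core within these four compounds, but it does not show which part of the core is responsible or how the change would behave on a further core.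

Still open, going by these compounds, is whether other groups on this aromatic carbon, such as an amine, a methoxy group or a carboxylic acid, would follow either step. Also open, on these data alone, is which feature separating the two cores governs the step; each core appears here only with bromo and nitro at this place.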